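Replacing the indolyl group of compound 2 with a chlorophenoxy group

This account rests on a few compounds, and the source may have more. Where it says the series, first, only, none or still open, it means among the compounds named here.

Compound 1: `Cc1nn(C)c(-n2cccc2)c1/C=N/OCc1ccc(C(=O)OC(C)(C)C)cc1` — 2.67 ug/mL in a functional assay on XF498 cells (Homo sapiens) for cytotoxicity; a higher number here means a weaker inhibitor, a lower number a stronger inhibitor
Compound 2: `Cc1nn(C)c(-n2ccc3ccccc32)c1/C=N/OCc1ccc(C(=O)OC(C)(C)C)cc1` — 1.61 ug/mL in this assay

Among the measured compounds shown here, compound 2 has the lowest of the two numbers measured so far, and its nearest neighbour is compound 1; the step between them, a 1.7-fold lower number from compound 1 to compound 2 (0.22 log units; within the scatter), lies within the scatter. Compound 3 `Cc1nn(C)c(Oc2ccc(Cl)cc2)c1/C=N/OCc1ccc(C(=O)OC(C)(C)C)cc1` has not been measured. It differs from compound 2 in one place: 4-chlorophenoxy in place of 1H-indol-1-yl on an aromatic carbon. For the measured compounds named here, only one measured step bears on this position, namely a 1.7-fold lower number from compound 1 to compound 2 (0.22 log units; within the scatter), which exchanged one nitrogen-linked ring system for a larger one without a change beyond the scatter. Going by the values given here, the new group is joined through oxygen rather than nitrogen, and no measured pair shows such an exchange. The step of a 1.4-fold higher number from compound 2 to compound 3 (0.14 log units; within the scatter) is therefore expected to stay within the scatter, with the range widened for the untested linkage. Compound 3 is estimated at 2.2 ug/mL, between 0.9 ug/mL and 5.5 ug/mL.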

Compound 3, half-maximal inhibitory concentration: 0.02 ug/mL
The estimate for compound 3 lay 110-fold (2.04 log units) above the measured number; measured number below the stated range.
By their numbers in this assay, from the lowest: compound 3; then compounds 2 and 1 (each within the scatter of the next).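

In this assay, this position on the aromatic carbon next to the ring nitrogen turned out to be highly sensitive to the group it carries: 4-chlorophenoxy in place of 1H-indol-1-yl gave an 81-fold lower number from compound 2 to compound 3 (1.91 log units; beyond the scatter), and the same group in place of 1H-pyrrol-1-yl gave a 130-fold lower number from compound 1 to compound 3 (2.13 log units; beyond the scatter). The earlier exchange between the two nitrogen-linked ring systems had stayed within the scatter, so it gave no sign that the position could produce a change of this size. Nothing measured here accounts for that change.

The change replaces the nitrogen link with oxygen and also brings in chlorine, so these compounds cannot show which of the two carries the step. From the compounds shown here alone, an unsubstituted phenoxy group or a 4-chloroanilino group at this position would separate the two, and the role of the tert-butyl ester, compared with a free carboxylic acid, also remains open.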